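Configuration at one ring carbon in a small series

The source may report more compounds than this note shows. Statements on the series, on what has been measured and on what is new or still open speak of the compounds shown alone.

In a functional assay on A549 cells (Homo sapiens) for inhibition, read by MTT assay, with a stated time of 72 h (a lower number here means a stronger inhibitor, a higher number a weaker inhibitor), compound 1 (`CC1=NN(c2ccccc2)C(=O)[C@]12C(=O)C=CC[C@@H]2c1ccc(C)cc1`) gives 8600 nM, compound 2 (`CC1=NN(c2ccccc2)C(=O)[C@@]12C(=O)C=CC[C@H]2c1ccccc1`) gives 3770 nM and compound 3 (`CC1=NN(c2ccccc2)C(=O)[C@@]12C(=O)C=CC[C@@H]2c1ccccc1`) gives 7770 nM. Compound 3 thus lies within the scatter of compound 1 and has a higher number than compound 2. Compound 4 (`CC1=NN(c2ccccc2)C(=O)[C@]12C(=O)C=CC[C@@H]2c1ccccc1`) departs from compound 3 in this way: the two compounds have the same atoms and bonds and differ only in configuration as drawn: 1 of 2 stereo elements differ; a stereocentre at a saturated ring carbon is drawn R in compound 3 and S in compound 4. Within the data shown here, the one measured step that bears on this is a 2.1-fold higher number from compound 2 to compound 3 (0.31 log units; beyond the scatter), a modest step that likewise changes configuration alone. Since that step only just clears the scatter, a move of no greater size is expected in this assay. The expected change is a 1.2-fold lower number from compound 3 to compound 4 (0.08 log units; within the scatter), slightly downward and probably within the scatter. For compound 4 the estimate is 6500 nM, with an expected range of 3000 nM to 13000 nM.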

Compound 4, half-maximal inhibitory concentration: 9180 nM
Beside the measured number, compound 4's estimate is 1.4-fold (0.15 log units) below it; the range from low to high includes it.
By their numbers in this assay, from the lowest: compound 2; then compounds 3, 1 and 4 (each within the scatter of the next).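

In this assay, inverting one stereocentre at a saturated ring carbon gives a 1.2-fold higher number from compound 3 to compound 4 (0.07 log units; within the scatter), so this change of configuration does not separate the pair. Inverting both stereocentres gives a 2.4-fold higher number from compound 2 to compound 4 (0.39 log units; beyond the scatter), which leaves compound 2 with the lowest number among the three stereoisomers shown. Hydrogen in place of methyl on an aromatic carbon gives a 1.1-fold higher number from compound 1 to compound 4 (0.03 log units; within the scatter), so this change does not separate that pair either.

The compounds shown leave open how an amine or a carboxylic acid on that aromatic carbon would read. They also leave open whether the configuration of compound 2 would keep its lower number with such a group.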